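Methyl on the Ring Nitrogen of a Hydrazine Analogue

The compounds below may be only part of what the source reports. "The series", "measured", "known", "first", "only" and "open" are said of these compounds alone.

In a functional assay on the whole organism with Mus musculus as the target, with a stated time of 1 h (on this read-out higher numbers stand for an effect only at larger amounts of compound and lower numbers for an effect already at smaller amounts), compound 1 `CNNc1nnc(-c2ccccc2C)s1` reaches only the limit of the test, reported as > 100 mg/kg. Compound 2 `Cc1ccccc1-c1nnc(NNC(c2ccccc2)c2ccccc2)s1` likewise gives only a limit in this assay, namely > 100 mg/kg. For the measured compounds named here, both results thus sit at the limit of > 100 mg/kg in this assay, at which 2 of the 2 values shown sit, so no measured step between the two can be drawn, and where compound 2 stands is known only as far as that limit. Compound 3 `Cc1ccccc1-c1nnc(N(C)NC(c2ccccc2)c2ccccc2)s1` has not yet been tested. It differs from compound 2 by methyl in place of hydrogen on a nitrogen on an aromatic ring. Going by the values given here, with no measured step to lean on, the expected change in this assay is a number no higher from compound 2 to compound 3 (the limit leaves the size open), that is, nothing beyond the usual scatter. Compound 3 is therefore expected to return a limit again rather than a number. As a figure, compound 3 is estimated at 100 mg/kg, with a range from 30 mg/kg to 300 mg/kg.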

Compound 3, dose for half-maximal effect: > 200 mg/kg
Compound 3: a limit, no number (the forecaster's own chance of this, stated with the estimate: 75%); at least 2.0-fold (0.30 log units) between middle value and limit.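

Compound 2 and compound 3 each give only a limit in this assay, so the step of methyl in place of hydrogen on a nitrogen on an aromatic ring cannot be read. The compounds shown leave open whether this methyl changes the dose for half-maximal effect at all.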